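The source may hold more compounds than are shown below. What is called first, only, known or untested is meant among the compounds shown, and "the series" means these compounds.

Of the compounds shown here, three that share one core have been measured in an assay on isolated protein for inhibition of N-acylethanolamine-hydrolyzing acid amidase (Homo sapiens), read by fluorescence, with a stated time of 90 min; a lower number here means a stronger inhibitor, a higher number a weaker inhibitor. Compound 1 `N#CN1CC(OCc2ccc(-c3ccccc3)cc2)C1` gives 2.8 nM and stands at the highest of the three numbers. Compound 2 `N#CN1CC(OCc2ccc(-c3cccc(OCc4ccccc4)c3)cc2)C1`, which bears an added benzyloxy group, gives 1.4 nM; the step of a 2.0-fold lower number from compound 1 to compound 2 (0.30 log units; within the scatter) stays within the scatter. Compound 3 `Cc1ccc(-c2ccc(COC3CN(C#N)C3)cc2)cc1`, which carries a methyl in place of hydrogen on an aromatic carbon, gives 0.46 nM; the step of a 6.1-fold lower number from compound 1 to compound 3 (0.78 log units; beyond the scatter) is a modest one beyond the scatter.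

Compound 4 `N#CN1CC[C@H](OCc2ccc(-c3ccccc3)cc2)C1` has not yet been measured. It differs from compound 1 at the other end of the molecule: 1-cyanopyrrolidin-3-yl in place of 1-cyanoazetidin-3-yl on an oxygen on a saturated carbon. The change brings one extra carbon into the ring and a defined stereocentre, while keeping the nitrile, the count of hydrogen-bond donors and acceptors and the absence of charge unchanged.

Neither measured step bears on this change, since both alter a substituent on an aromatic carbon and leave the ring on the oxygen untouched. Within the data shown here, no step of this kind is therefore available as a guide, and the expectation rests only on the small size of the change. The estimate for compound 4 in this assay is 4 nM, within a range from 1 nM to 15 nM, which means an expected step of a 1.4-fold higher number from compound 1 to compound 4 (0.15 log units; within the scatter).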

Compound 4, half-maximal inhibitory concentration: 315 nM
Compound 4: middle estimate off by 79-fold (1.90 log units), on the low side; the measured number lies above the stated range.
By their numbers in this assay, from the lowest: compound 3; then compounds 2 and 1 (each within the scatter of the next); then compound 4.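

In this assay the ring on the oxygen proves far more sensitive than the aromatic carbons changed so far: moving from 1-cyanoazetidin-3-yl to 1-cyanopyrrolidin-3-yl produces a 110-fold higher number from compound 1 to compound 4 (2.05 log units; beyond the scatter) and so costs much of the inhibition, whereas the methyl change gave only a 6.1-fold lower number from compound 1 to compound 3 (0.78 log units; beyond the scatter) and the benzyloxy change gave a 2.0-fold lower number from compound 1 to compound 2 (0.30 log units; within the scatter) in the direction of a lower number. A single added ring carbon, with the nitrile retained and the counts of hydrogen-bond donors and acceptors unchanged, is thus enough to accompany a large loss, so keeping these features does not by itself preserve the result at this position. Nothing available explains the size of this step, and the change also adds a defined stereocentre, so the effects of ring size and stereochemistry cannot be separated here.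

The mirror-image form of compound 4 would show whether the stereocentre matters in this five-membered ring. From the compounds shown here alone, a 1-cyanopiperidin-3-yl group on the same oxygen would show whether the number keeps rising as the ring grows, and whether the methyl of compound 3 can offset any of this loss also remains open.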